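The compounds below may be only part of what the source reports. "The series", "measured", "known", "first", "only" and "open" are said of these compounds alone.

Working notes on the series. In a physicochemical assay for lipophilicity, read by HPLC, in phosphate buffer, measured as chromatographic lipophilicity, at pH 7.4 (on this read-out lower numbers stand for lower lipophilicity and higher numbers for higher lipophilicity), compound 3 `COc1ccc2nc(C)cc(OCC(=O)Nc3cccc(C)c3)c2c1` gives 4.83. Compound 1 `COc1cc2nc(C)cc(OCC(=O)Nc3cc(C)cc(C)c3)c2cc1OC` gives 4.84 in this assay, a number that sits within the scatter of the reading for compound 3. Compound 2 `COc1ccc2nc(C)cc(OC(C)C(=O)Nc3cc(C)cc(C)c3)c2c1` gives 5.76 in this assay, a reading beyond the scatter and higher than that of compound 3, so compound 3 and compound 1 share the low end of the three numbers. Compound 4 `COc1ccc2nc(C)cc(OCC(=O)Nc3cc(F)cc(F)c3)c2c1` is not yet measured in this assay. It differs from compound 3 by 3,5-difluorophenyl in place of 3-methylphenyl on an amide-type nitrogen. Among the compounds with values here, no step between measured compounds isolates this change, so the expectation rests on the structures alone: a small upward step, estimated as a number 0.22 log units higher from compound 3 to compound 4 (within the scatter), is expected, and it may not exceed the scatter. For compound 4 the estimated reading in this assay is 5.05, with a range from 4.6 to 5.5.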

Compound 4, distribution coefficient: 5.13
For compound 4 the middle estimate is 0.08 log units below the measured one; the measured number falls inside the stated range.
By their numbers in this assay, from the lowest: compounds 3, 1 and 4 (each within the scatter of the next); then compound 2.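

In this assay, the series now has a single-place step at the amide-type nitrogen: 3,5-difluorophenyl in place of 3-methylphenyl gives a number 0.30 log units higher from compound 3 to compound 4 (within the scatter). At this place and on this core, the two groups are therefore not separated on this read-out. No supporting measurement bears on this step.

As far as these compounds go, whether a phenyl group carrying an amine or a carboxylic acid on the same nitrogen would give a step beyond the scatter remains open. So does whether the same exchange gives a similar step on the core of compound 1.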